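This account rests on a few compounds, and the source may have more. Where it says the series, first, only, none or still open, it means among the compounds named here.

Compound 1, with the structure `COC(=O)[C@@]1(C)CCC=C2[C@@H]1CC[C@@H](C)[C@]2(C)Cc1c[nH]c2ccc(Br)cc12`, and compound 2, with the structure `COC(=O)[C@@]1(C)CCC=C2[C@@H]1CC[C@@H](C)[C@]2(C)Cc1c[nH]c2ccc(Cl)cc12`, are built on one core; compound 3, with the structure `COC(=O)[C@@]1(C)CC[C@@H]2C3=C1CC[C@@H](C)[C@]3(C)C[C@@H]1c3cc(Br)ccc3N[C@H]21`, and compound 4, with the structure `COC(=O)[C@@]1(C)CC[C@@H]2C3=C1CC[C@@H](C)[C@]3(C)C[C@@H]1c3cc(Cl)ccc3N[C@H]21`, share a second core that has the same atoms joined differently. The difference between the two cores is not broken down here.

In a functional assay on WiDr cells (Homo sapiens) for inhibition, read by sulforhodamine B assay, with a stated time of 48 h (on this read-out lower numbers stand for stronger inhibition of growth and higher numbers for weaker inhibition of growth), compound 1 gives 20000 nM. Compound 2, in this assay, gives 20000 nM. The step of no change at the digits printed from compound 1 to compound 2 (within the scatter) rests on the change (chloro in place of bromo on an aromatic carbon). In this assay compound 3 gives 55000 nM, the highest number of the three measured compounds, and its gaps to compound 1 and to compound 2 both lie beyond the scatter.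

Compound 4 differs from compound 3 by the change (chloro in place of bromo on an aromatic carbon). Within the data shown here, this is the same kind of change as the one from compound 1 to compound 2, but the place is not the same word for word: in compound 3 the aromatic ring is part of a fused or bridged system of five rings, whereas in compound 1 it is part of a fused or bridged system of two rings.

The step of no change at the digits printed from compound 3 to compound 4 (within the scatter) in this assay is expected to be small, because the same kind of change gave no change at the digits printed from compound 1 to compound 2 (within the scatter). Compound 4 is therefore estimated at 55000 nM in this assay, expected to fall between 25000 nM and 120000 nM.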

Compound 4, concentration for 50% growth inhibition: 48000 nM
Estimate against measurement, compound 4: 1.1-fold (0.06 log units) above, within the range that was stated.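

In this assay, chloro in place of bromo on an aromatic carbon of the second core gives a 1.1-fold lower number from compound 3 to compound 4 (0.06 log units; within the scatter), so the exchange does not separate these two compounds on growth inhibition. Set beside the step on the first core, the same exchange reads alike on both cores: the same change on two cores in this assay, no change at the digits printed (within the scatter) from compound 1 to compound 2 and a 1.1-fold lower number (0.06 log units; within the scatter) from compound 3 to compound 4, 1.1-fold (0.06 log units) apart, within the scatter of two such steps. This shows that, for this one pair of halogens in this one cell assay, the result on one core would have served as a guide to the result on the other, but as neither step lies beyond the scatter, the agreement is between two steps that show no measurable effect, and it does not show that a change with a real effect on growth inhibition would carry over from one core to the other in the same way.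

The compounds shown leave open what other groups on this aromatic carbon, such as a methoxy group, a nitrile or an amine, would do on either core, and whether any of them would give a step beyond the scatter. They also leave open what a carboxylic acid or an amide in place of the methyl ester would do on the two cores in this assay.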